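Adding a Second Methoxy Group on a Different Core

The compounds below may be only part of what the source reports. "The series", "measured", "known", "first", "only" and "open" are said of these compounds alone.

Compound 1 `COc1ccc(-c2nc3cc(/C(C)=N/NC(N)=S)ccc3[nH]2)cc1` is the starting point. In an ADME assay on MDBK cells (Bos taurus) for cytotoxicity, read by MTT assay, with a stated time of 96 h (a higher number here means that more compound is tolerated, a lower number that less compound is tolerated), compound 1 gives 13000 nM. Compound 2 `COc1ccc(-c2nc3cc(/C(C)=N/NC(N)=S)ccc3[nH]2)c(OC)c1` carries one more methoxy group than compound 1; the counted difference is methoxy in place of hydrogen on an aromatic carbon. For compound 2 this assay reports only a limit, > 100000 nM, and not a number. The step of an at least 7.6-fold higher number from compound 1 to compound 2 (0.88 log units; beyond the scatter) is therefore a lower bound, set by the limit of > 100000 nM in this assay, at which 1 of the 3 values shown sits.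

Compound 3 `COc1ccc(-c2nc3cc(/C(C)=N/NC(N)=S)ccc3n2C2CCCCC2)cc1` differs from compound 1 in its core, where (cyclohexyl in place of hydrogen on an aromatic nitrogen). In this assay compound 3 gives 32000 nM, and the step of a 2.5-fold higher number from compound 1 to compound 3 (0.39 log units; beyond the scatter) shows that more of compound 3 is tolerated than of compound 1.

Compound 4 `COc1ccc(-c2nc3cc(/C(C)=N/NC(N)=S)ccc3n2C2CCCCC2)c(OC)c1` has not been measured. It stands to compound 3 as compound 2 stands to compound 1: methoxy in place of hydrogen on an aromatic carbon. The surroundings of the entering methoxy read the same in both pairs, so this is the same change made on a different core. Because the same change earlier gave an at least 7.6-fold higher number from compound 1 to compound 2 (0.88 log units; beyond the scatter), a step of similar size, a 4.7-fold higher number from compound 3 to compound 4 (0.67 log units; beyond the scatter), is expected here. For compound 4 the expected value in this assay is 150000 nM, with a likely range from 60000 nM to 400000 nM. Such a step would carry compound 4 to a value that this assay may again report only as a limit.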

Compound 4, half-maximal cytotoxic concentration: > 100000 nM
Compound 4 gave a limit, no number; the forecaster's own chance of this, stated with the estimate: 70%; the middle value is on the limit's open side.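

In this assay, the change from 4-methoxyphenyl to 2,4-dimethoxyphenyl points the same way on the core carrying cyclohexyl as on the core of compound 1, with an at least 3.1-fold higher number from compound 3 to compound 4 (0.49 log units; beyond the scatter), so more compound is tolerated after the change on both cores. This shows that the direction carried over between these two pairs, but not that the size did, and two pairs are too few to make a rule for the series: the same change on two cores in this assay, an at least 7.6-fold higher number (0.88 log units; beyond the scatter) from compound 1 to compound 2 and an at least 3.1-fold higher number (0.49 log units; beyond the scatter) from compound 3 to compound 4; the limit leaves it open whether they differ The step between compound 2 and compound 4 cannot be read, because both compounds give a limit and not a number: the limit of > 100000 nM in this assay, at which 2 of the 4 values shown sit.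

The compounds shown leave open whether another group entering at the same place, such as a hydroxy group, an amine or a longer ethoxy chain, would move the number in the same direction. They also leave open whether the methoxy change would behave alike with a different group in place of cyclohexyl on the aromatic nitrogen, such as a methyl or a benzyl group.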